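Phenyl for carboxy on the saturated chain of compound 3

A few compounds are considered here, and "the series" means these few. Any claim that something is new, unique, unknown or untested is made for them only; others in the source may bear on it.

Of the compounds shown here, three on the shared core have been measured in a functional assay for inhibition, with Homo sapiens as the target; on this read-out higher numbers stand for weaker inhibition and lower numbers for stronger inhibition. Compound 1 `CCOC(=O)/C(=C\c1cccc(OCC(=O)OC(C)(C)C)c1)c1nc(-c2ccccc2)c(-c2ccccc2)o1` is reported only as a limit, > 60000 nM. Compound 2 `CCOC(=O)/C(=C\c1cccc(OCC(=O)O)c1OC)c1nc(-c2ccccc2)c(-c2ccccc2)o1` gives 130 nM. Compound 3 `O=C(O)COc1cccc(CC(C(=O)O)c2nc(-c3ccccc3)c(-c3ccccc3)o2)c1` gives 14000 nM, the higher of the two actual numbers and well beyond the scatter from the value of compound 2.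

The next compound changes one place in compound 3. Compound 4 `O=C(O)COc1cccc(CC(c2ccccc2)c2nc(-c3ccccc3)c(-c3ccccc3)o2)c1` has phenyl in place of carboxy on a saturated chain carbon bound to an aromatic carbon and a saturated chain carbon. It keeps the other carboxy, which is also free in compound 2 and compound 3 but not in compound 1.

Among the measured compounds shown here, no measured single-place step bears directly on this change, so the expectation is loose. It leans on compound 2, which has no free carboxy at the corresponding carbon and gives 130 nM, although compound 2 also differs from compound 3 elsewhere. A move to a lower number in this assay, beyond the scatter, is expected, estimated as a 9.3-fold lower number from compound 3 to compound 4 (0.97 log units; beyond the scatter). Compound 4 is estimated at 1500 nM, with an expected range from 200 nM to 12000 nM.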

Compound 4, half-maximal inhibitory concentration: 23200 nM
For compound 4 the middle estimate is 15-fold (1.19 log units) below the measured one; measured number above the stated range.
By their numbers in this assay, from the lowest: compound 2; then compounds 3 and 4 (each within the scatter of the next). At a limit, above all of these: compound 1.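

In this assay the exchange of carboxy for phenyl on this saturated chain carbon gives a 1.7-fold higher number from compound 3 to compound 4 (0.22 log units; within the scatter) and so leaves the two groups unresolved at this place. At this carbon, then, the read-out does not depend on a free carboxy in any way this pair can show, and a six-membered aromatic ring of carbon only, with its larger count of heavy atoms, stands there with no separable result, while the other carboxy is kept on both sides of the step. Only compound 1 sits at a limit, and this step joins two actual numbers: the limit of > 60000 nM in this assay, at which 1 of the 4 values shown sits.

What sets compound 2 apart remains outside this step, as compound 2 differs from compound 3 and compound 4 in more than one place. Open at this carbon are an amine, a hydroxyl group or a methyl group, and with them the question of whether any group here moves the number beyond the scatter while the other carboxy stays in place.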